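Five-membered ring exchange on the shared core

This account rests on a few compounds, and the source may have more. Where it says the series, first, only, none or still open, it means among the compounds named here.

Going by the values given here, compound 2 `Nc1nnc(-c2ccccc2Sc2ccccc2)o1` has the lower of the two numbers measured so far. In a functional assay on the whole organism (strain NMRI) for inhibition, with Mus musculus as the target, in the formalin test, with a stated time of 30 min, at a dose of 30 umol/kg by the intraperitoneal route (a lower number here means less inhibition, a higher number more inhibition at the dose given (going by the name of the read-out)), compound 2 gives 63.7%. Its nearest neighbour is compound 1 `S=c1[nH]nc(-c2ccccc2Sc2ccccc2)o1`, which in this assay gives 71.3%; the step of a number 7.6 percentage points lower from compound 1 to compound 2 (within the scatter) stays within the scatter. Compound 3 `S=c1[nH]nc(-c2ccccc2Sc2ccccc2)[nH]1` differs from compound 2 by a group of 6 heavy atoms (2 carbon, 3 nitrogen, 1 sulfur; one five-membered aromatic ring with 3 hetero atoms) in place of a group of 6 heavy atoms (2 carbon, 3 nitrogen, 1 oxygen; one five-membered aromatic ring with 3 hetero atoms), on an aromatic carbon. The entering group shares with compound 1 the sulfur and the double bond outside aromatic rings, while its ring carries nitrogen where the earlier rings carried oxygen. Among the compounds with values here, the only measured step bearing on this change is a number 7.6 percentage points lower from compound 1 to compound 2 (within the scatter), which was small. Within the data shown here, no measured compound carries the entering ring, so nothing beyond that step informs the expectation. The expected step of a number 4.3 percentage points higher from compound 2 to compound 3 (within the scatter) is therefore small, in either direction within the scatter. For compound 3 the estimate in this assay is 68%, with a range from 50% to 85%.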

Compound 3, a percentage reported as inhibition, in the whole organism at one dose (the size of the read-out at that dose, not a potency): 79.6%
The estimate for compound 3 lay 11.6 percentage points below the measured number; measured number inside the range.
By their numbers in this assay, from the lowest: compounds 2, 1 and 3 (each within the scatter of the next, the first and the last beyond it).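

In this assay, this position on an aromatic carbon now shows a ring exchange that registers beyond the scatter: replacing 5-amino-1,3,4-oxadiazol-2-yl with the sulfur-bearing ring gives a number 15.9 percentage points higher from compound 2 to compound 3 (beyond the scatter). The exchange between the two rings that both carry sulfur and a double bond outside aromatic rings, one with oxygen and the other with nitrogen in that place, gives a number 8.3 percentage points higher from compound 1 to compound 3 (within the scatter), which stays within the scatter and so does not separate those two compounds. No measurement on hand accounts for either step.

From the compounds shown here alone, the sulfur's own contribution remains open, as the step from compound 1 to compound 2 alone does not settle it: a number 7.6 percentage points lower from compound 1 to compound 2 (within the scatter). Also open, going by these compounds, is how an open-chain group at this position, such as a carboxylic acid or an amide, would compare with these five-membered rings.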